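This account rests on a few compounds, and the source may have more. Where it says the series, first, only, none or still open, it means among the compounds named here.

Compound 1 `O=C(OC1CCC(CN2CCN(c3cc(=O)c4cc(C(F)(F)F)cc([N+](=O)[O-])c4s3)CC2)CC1)c1ccco1`: 1%
Compound 2 `Nc1cc(C(F)(F)F)cc2c(=O)cc(N3CCN(CC4CCCCC4)CC3)sc12`: 0.9%

In an ADME assay on cells (Hepatocyte, Homo sapiens) for metabolic stability, with a stated time of 30 min (a higher number here means that more of the compound is left, a lower number that less of the compound is left), compound 1 gives 1% and compound 2 gives 0.9%, which places the two level within the scatter, with very little of either left. Compound 3 `O=c1cc(N2CCN(CC3CCC(O)CC3)CC2)sc2c([N+](=O)[O-])cc(C(F)(F)F)cc12` follows from compound 1 by one change: hydrogen in place of (furan-2-yl)carbonyl on an oxygen on a saturated carbon. Within the data shown here, no measured pair shows the size of such a change. Some rise beyond the scatter is still expected, as so little of compound 1 remains at 1%. The expected step is a number 11 percentage points higher from compound 1 to compound 3 (beyond the scatter). For compound 3 the estimate is 12%, with an expected range of 2% to 45%.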

Compound 3, percent of the compound remaining: 72.7%
The estimate for compound 3 lay 60.7 percentage points below the measured number; the whole stated range lies below it.
By their numbers in this assay, from the lowest: compounds 2 and 1 (each within the scatter of the next); then compound 3.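

At this place, on an oxygen on a saturated carbon, one change moves the read-out of this assay over a wide span: a number 71.7 percentage points higher from compound 1 to compound 3 (beyond the scatter). Compounds 1 and 2 stood level and gave no sign that a single place could carry a step of this size. Nothing at hand accounts for the step.

From the compounds shown here alone, whether the rise goes with the hydroxy itself or only with the loss of (furan-2-yl)carbonyl stays open. A methoxy group or an amine on that saturated carbon would separate the two readings.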